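From isopropyl to cyclohexyl on a saturated ring carbon

The source may hold more compounds than are shown below. What is called first, only, known or untested is meant among the compounds shown, and "the series" means these compounds.

Of the compounds shown here, three have been read so far in an ADME assay on Huh-7 cells (Homo sapiens) for cytotoxicity, with a stated time of 72 h; on this read-out lower numbers stand for higher toxicity in this test and higher numbers for lower toxicity in this test. Compound 1 (`CCOc1cccc2c1S(=O)(=O)N=C2C1=C(O)[C@H](C(C)C)N(Cc2ccccc2)C1=O`) gives > 33000 nM, which is a limit. Compound 2 (`CC(C)[C@H]1C(O)=C(C2=NS(=O)(=O)c3c(OCC(=O)N4CCOCC4)cccc32)C(=O)N1Cc1ccccc1`) gives > 33000 nM, also a limit. Compound 3 (`CCOc1cccc2c1S(=O)(=O)N=C2C1=C(O)[C@H](C(C)C)N(CCC(C)(C)C)C1=O`) gives > 33000 nM, again a limit. It therefore holds no position of its own within the series, which stands at the limit of > 33000 nM in this assay, at which 3 of the 3 values shown sit.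

Compound 4 (`CCOc1cccc2c1S(=O)(=O)N=C2C1=C(O)[C@H](C2CCCCC2)N(CCC(C)(C)C)C1=O`) carries cyclohexyl in place of isopropyl on a saturated ring carbon, next to the ring nitrogen: cyclohexyl in place of isopropyl on a saturated ring carbon.

Among the measured compounds shown here, the steps that bear on this are a step that the two limits leave unreadable from compound 1 to compound 2 and a step that the two limits leave unreadable from compound 1 to compound 3. Compound 1 thus offers no size to carry over, and neither step falls at this ring carbon. The expected step is an at least 1.1-fold lower number from compound 3 to compound 4 (0.04 log units; that floor lies within the scatter), with no change beyond the scatter expected in either direction. Compound 4 is estimated at 30000 nM, with an expected range of 12000 nM to 60000 nM.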

Compound 4, half-maximal cytotoxic concentration: > 33000 nM
Compound 4 gave a limit, no number; the forecaster's own chance of this, stated with the estimate: 75%; middle value at least 1.1-fold (0.04 log units) away from the limit.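

Compound 3 and compound 4 both sit at a limit in this assay, so the step between them cannot be read. The compounds shown leave open whether any member of this series gives a measured number rather than a limit: the limit of > 33000 nM in this assay, at which 4 of the 4 values shown sit.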